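Thiophene for phenyl on the imine of a pyrimidine series

The source may report more compounds than this note shows. Statements on the series, on what has been measured and on what is new or still open speak of the compounds shown alone.

Measured compounds:
Compound 1 `NS(=O)(=O)c1ccc(Nc2ncc(/N=C/c3ccccc3)c(NC3CCCC3)n2)cc1` gives 27000 nM
Compound 2 `NS(=O)(=O)c1ccc(Nc2ncc(/N=C/c3cccs3)c(NC3CCCC3)n2)cc1` gives 9950 nM
Compound 3 `CC(C)Nc1nc(Nc2ccc(N3CCN(C)CC3)cc2)ncc1/N=C/c1ccccc1` gives 12100 nM

These three compounds were tested in a functional assay on HT-29 cells (Homo sapiens) for antiproliferative activity, read by MTT assay; on this read-out higher numbers stand for weaker inhibition and lower numbers for stronger inhibition. Compound 1 and compound 2 share a core and differ in one place, (thiophen-2-yl in place of phenyl on a carbon with a double bond to nitrogen). That change gave a 2.7-fold lower number from compound 1 to compound 2 (0.43 log units; beyond the scatter). Compound 3 carries a different core; its difference from compound 1 is not broken down here, and the two values simply show that compound 3 gives a lower number than compound 1 in this assay, while compound 3 and compound 2 sit within the scatter of each other.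

Compound 4 `CC(C)Nc1nc(Nc2ccc(N3CCN(C)CC3)cc2)ncc1/N=C/c1cccs1` is not yet measured. It differs from compound 3 by thiophen-2-yl in place of phenyl on a carbon with a double bond to nitrogen, the same change as that made from compound 1 to compound 2, at the same kind of place. Among the compounds with values here, for compound 4 the expected step is a 2.4-fold lower number from compound 3 to compound 4 (0.38 log units; beyond the scatter), because a 2.7-fold lower number from compound 1 to compound 2 (0.43 log units; beyond the scatter) is the only precedent for this change, seen once, on a different core. Compound 4 is therefore estimated at 5000 nM in this assay. The expected range for compound 4 runs from 2000 nM to 12000 nM.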

Compound 4, half-maximal inhibitory concentration: > 100000 nM
Compound 4: a limit, no number (the forecaster's own chance of this, stated with the estimate: 5%); middle value at least 20-fold (1.30 log units) away from the limit.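

In this assay, compound 4 gives > 100000 nM, which is a limit of the assay and not a number. Thiophen-2-yl in place of phenyl on a carbon with a double bond to nitrogen gave an at least 8.2-fold higher number from compound 3 to compound 4 (0.91 log units; beyond the scatter), whereas the same change on the other core gave a 2.7-fold lower number from compound 1 to compound 2 (0.43 log units; beyond the scatter), so here the change did not carry from one core to the other with its direction kept: the same change on two cores in this assay, a 2.7-fold lower number (0.43 log units; beyond the scatter) from compound 1 to compound 2 and an at least 8.2-fold higher number (0.91 log units; beyond the scatter) from compound 3 to compound 4, at least 22-fold (1.35 log units) apart, beyond the scatter of two such steps. This shows that the earlier step cannot be relied on across these two cores, but with one pair per core it does not show how large the step on the core of compound 3 really is, nor which feature of the cores sets the difference, and the limit leaves the size of that step open: the limit of > 100000 nM in this assay, at which 1 of the 4 values shown sits.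

The compounds shown leave open which of the places where the two cores differ decides the direction of the step. They also leave open whether another ring on the imine carbon, such as furan-2-yl or a pyridine, would follow compound 2 or compound 4.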